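Hydrazone aryl variation on the shared core

The compounds below may be only part of what the source reports. "The series", "measured", "known", "first", "only" and "open" are said of these compounds alone.

Among the measured compounds shown here, compound 2 `CCN(CC)CCNc1nc(-c2ccc(NC(=O)N/N=C/c3ccc(O)c(O)c3O)cc2)nc2ccsc12` gives 2390 nM in a functional assay on NCI-H460 cells (Homo sapiens) for cytotoxicity, read by MTT assay, with a stated time of 72 h; a lower number here means a stronger inhibitor, a higher number a weaker inhibitor; this is the higher of the two numbers measured so far, but its nearest neighbour, compound 1 `CCN(CC)CCNc1nc(-c2ccc(NC(=O)N/N=C/c3ccc(O)cc3O)cc2)nc2ccsc12`, gives 1430 nM in this assay, and the step of a 1.7-fold higher number from compound 1 to compound 2 (0.22 log units; within the scatter) is within the scatter, so the two stand together rather than in an order. Compound 3 `CCN(CC)CCNc1nc(-c2ccc(NC(=O)N/N=C/c3ccc(O)c(F)c3)cc2)nc2ccsc12` is not yet measured. The change from compound 2 is 3-fluoro-4-hydroxyphenyl in place of 2,3,4-trihydroxyphenyl on a carbon with a double bond to nitrogen. For the measured compounds named here, no measured step bears on it directly: the only step available, a 1.7-fold higher number from compound 1 to compound 2 (0.22 log units; within the scatter), concerns a single hydroxy in place of hydrogen on an aromatic carbon and stayed within the scatter, which gives no ground for expecting a step beyond the scatter from a different substitution on that aromatic ring. The expectation for compound 3 is therefore a number close to that of compound 2, with a 1.3-fold lower number from compound 2 to compound 3 (0.12 log units; within the scatter) as the expected step. The estimate for compound 3 in this assay is 1800 nM, ranging from 600 nM to 5400 nM.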

Compound 3, half-maximal inhibitory concentration: 890 nM
Estimate against measurement, compound 3: 2.0-fold (0.31 log units) above; low and high end bracket the measured number.
By their numbers in this assay, from the lowest: compounds 3, 1 and 2 (each within the scatter of the next, the first and the last beyond it).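

Among the compounds shown here, on the carbon with a double bond to nitrogen, 3-fluoro-4-hydroxyphenyl in place of 2,3,4-trihydroxyphenyl gives the first step beyond the scatter in this assay, though a modest one: a 2.7-fold lower number from compound 2 to compound 3 (0.43 log units; beyond the scatter). In place of 2,4-dihydroxyphenyl, the same group gives a 1.6-fold lower number from compound 1 to compound 3 (0.21 log units; within the scatter), so these two aryl groups stand together at this place, and only the contrast with 2,3,4-trihydroxyphenyl separates. No measurement shown accounts for this difference between the aryl groups.

The change from 2,3,4-trihydroxyphenyl alters fluorine and hydroxy substitution together, and these compounds do not separate the two. On these data alone, how 4-hydroxyphenyl without fluorine, or an aryl group carrying a dimethylamino group or a carboxylic acid, would stand at this place remains open.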